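Notes on the 4-fluorophenyl to 4-chlorophenyl step

This account rests on a few compounds, and the source may have more. Where it says the series, first, only, none or still open, it means among the compounds named here.

In an ADME assay on HEK-293T cells (Homo sapiens) for cytotoxicity, read by MTT assay, with a stated time of 72 h (a lower number here means a stronger inhibitor, a higher number a weaker inhibitor), compound 1 (`O=C(Nc1nc2ccc(Cl)cc2s1)c1cn(-c2ccccc2)nc1-c1ccc(F)cc1`) gives 45700 nM as a measured number. Compound 2 (`Cc1ccc2nc(NC(=O)c3cn(-c4ccccc4)nc3-c3ccc(F)cc3)sc2c1`) reads > 50000 nM and this is a limit of the assay, not a number. Its standing is therefore known only as the limit of > 50000 nM in this assay, at which 1 of the 2 values shown sits, and nothing finer can be said.

Compound 3 (`Cc1ccc2nc(NC(=O)c3cn(-c4ccccc4)nc3-c3ccc(Cl)cc3)sc2c1`) differs from compound 2 by chloro in place of fluoro on an aromatic carbon and the change is chloro in place of fluoro on an aromatic carbon, para to a large group. Going by the values given here, the one measured step is an at least 1.0-fold higher number from compound 1 to compound 2 (0.03 log units; that floor lies within the scatter) and it stays within the scatter. That step is methyl in place of chloro on an aromatic carbon, a different exchange, so it bears on this one only loosely. Among the compounds with values here, no measured step covers the 4-fluorophenyl group.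

Within the data shown here, with compound 2 as the starting point and an at least 1.0-fold higher number from compound 1 to compound 2 (0.03 log units; that floor lies within the scatter) as the only guide, no shift beyond the scatter is expected in this assay and no direction can be given. The expected step is a number no higher from compound 2 to compound 3 (the limit leaves the size open) and it would lie within the scatter. Compound 3 is estimated at 50000 nM with an expected range of 25000 nM to 100000 nM and may well return only a limit.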

Compound 3, half-maximal inhibitory concentration: 35600 nM
Estimate against measurement, compound 3: 1.4-fold (0.15 log units) above; low and high end bracket the measured number.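

The 4-fluorophenyl to 4-chlorophenyl exchange now has a step of its own in this assay, the first at this place in the series: an at least 1.4-fold lower number from compound 2 to compound 3 (0.14 log units; that floor lies within the scatter). With chloro in place of fluoro, compound 3 gives 35600 nM, a measured number and not a limit, so this end of the series now has a value to compare later changes against. The floor of the step shows no shift beyond the scatter, but the true size of the step cannot be read because compound 2 carries only a limit of the assay: the limit of > 50000 nM in this assay, at which 1 of the 3 values shown sits.

Still open, as far as these compounds go, is whether a group of another kind at this place, such as an amine or a carboxylic acid in place of chloro, would move the number in this assay beyond the scatter. Also open, from the compounds shown here alone, is how the same exchange of fluoro for chloro would read with a measured number at both ends of the step, and whether it would read alike with chloro instead of methyl on the shared core.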